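Pyridin-3-yl amide in a paw edema series

The source may hold more compounds than are shown below. What is called first, only, known or untested is meant among the compounds shown, and "the series" means these compounds.

Measured in a functional assay on the whole organism for inhibition, with Rattus norvegicus as the target, read by paw edema, at a dose of 100 mg/kg by the oral route; a higher number here means more inhibition at the dose given (going by the name of the read-out), a lower number less inhibition:
compound 1 `CNC(=O)c1c(O)c2cccnc2n(-c2ccccc2)c1=O`: 9.6%
compound 2 `O=C(Nc1ccccc1)c1c(O)c2cccnc2n(-c2ccccc2)c1=O`: 4.6%
compound 3 `O=C(Nc1ccc([N+](=O)[O-])cc1)c1c(O)c2cccnc2n(-c2ccccc2)c1=O`: -7.6%

Compound 2 stands second highest of the three numbers. Its gap to compound 1 is within the scatter (a number 5 percentage points lower from compound 1 to compound 2 (within the scatter)), whereas its gap to compound 3 lies beyond it (a number 12.2 percentage points lower from compound 2 to compound 3 (beyond the scatter)). Compound 4 `O=C(Nc1cccnc1)c1c(O)c2cccnc2n(-c2ccccc2)c1=O` differs from compound 2 in one place: pyridin-3-yl in place of phenyl on an amide-type nitrogen. Among the measured compounds shown here, no measured step exchanges one aromatic ring for another; the steps at this amide nitrogen are a number 5 percentage points lower from compound 1 to compound 2 (within the scatter) and a number 17.2 percentage points lower from compound 1 to compound 3 (beyond the scatter), and the step on the ring itself is a number 12.2 percentage points lower from compound 2 to compound 3 (beyond the scatter). The expected step from compound 2 to compound 4 in this assay is a number 1.6 percentage points lower from compound 2 to compound 4 (within the scatter), not beyond the scatter. Compound 4 is thus estimated at 3%, between -12% and 16%.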

Compound 4, a percentage reported as inhibition, in the whole organism at one dose (the size of the read-out at that dose, not a potency): 30.3%
Beside the measured number, compound 4's estimate is 27.3 percentage points below it; measured number above the stated range.
By their numbers in this assay, from the lowest: compound 3; then compounds 2 and 1 (each within the scatter of the next); then compound 4.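

In this assay the aromatic ring on the amide-type nitrogen proved able to raise the number: pyridin-3-yl in place of phenyl gave a number 25.7 percentage points higher from compound 2 to compound 4 (beyond the scatter) while the earlier changes here had left the number level or lowered it. The same group also stands clear of methyl and 4-nitrophenyl, with a number 20.7 percentage points higher from compound 1 to compound 4 (beyond the scatter) and a number 37.9 percentage points higher from compound 3 to compound 4 (beyond the scatter) both beyond the scatter. Nothing available accounts for this rise.

As far as these compounds go, it remains open whether pyridin-2-yl or pyridin-4-yl on this nitrogen would give a similar number. Also open, from the compounds shown here alone, is whether a dimethylamino group on the pyridine ring would preserve it.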